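Shortening the Phenethyl Arm: From Compound 3 to Compound 4

The source may report more compounds than this note shows. Statements on the series, on what has been measured and on what is new or still open speak of the compounds shown alone.

Of the compounds shown here, three sharing one core have been measured in an in vitro functional assay on cells for agonist activity at Bombesin receptor subtype-3 (Mus musculus), read by luminescence and calcium flux; a lower number here means that less compound is needed, a higher number that more compound is needed for the effect. Compound 1 `Cc1cccc(Cc2cnc(CCc3ccc(-c4ccccc4C(=O)O)cc3)[nH]2)c1` gives 75 nM, compound 2 `CC(C)(C)Cc1cnc(CCc2ccc(-c3ccccc3C(=O)O)cc2)[nH]1` gives 6.3 nM, and compound 3 `O=C(O)c1ccccc1-c1ccc(CCc2ncc(CCc3ccccc3)[nH]2)cc1` gives 174 nM. Compound 3 therefore stands highest of the three numbers: the step of a 2.3-fold higher number from compound 1 to compound 3 (0.37 log units; beyond the scatter) is modest, while the step of a 28-fold higher number from compound 2 to compound 3 (1.44 log units; beyond the scatter) is large, so compound 3 needs the most compound of the set.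

Compound 4 `O=C(O)c1ccccc1-c1ccc(CCc2ncc(Cc3ccccc3)[nH]2)cc1` has not yet been measured. It differs from compound 3 in one place: phenyl in place of benzyl on a saturated chain carbon bound to an aromatic carbon. Cut one bond further out, the same difference reads phenethyl to benzyl. Going by the values given here, the step that bears on it is the one from compound 1, where a 2.3-fold higher number from compound 1 to compound 3 (0.37 log units; beyond the scatter) accompanied the removal of a methyl together with a shortening of the chain; the large step of a 28-fold higher number from compound 2 to compound 3 (1.44 log units; beyond the scatter) concerns a different group and speaks only to the cost of the phenethyl arm itself. A return toward the level of compound 1 is therefore expected, as a modest decrease in the number. Compound 4 is estimated at 100 nM, within 35 nM to 300 nM, which is expected to mean a step of a 1.7-fold lower number from compound 3 to compound 4 (0.24 log units; within the scatter).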

Compound 4, half-maximal effective concentration: 11 nM
Compound 4: middle estimate off by 9.1-fold (0.96 log units), on the high side; the measured number lies below the stated range.
By their numbers in this assay, from the lowest: compounds 2 and 4 (each within the scatter of the next); then compound 1; then compound 3.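

In this assay, the length of the chain at this position counts for far more than compound 1 and compound 3 had suggested: phenyl in place of benzyl on a saturated chain carbon bound to an aromatic carbon, with the aromatic ring itself kept, gives a 16-fold lower number from compound 3 to compound 4 (1.20 log units; beyond the scatter). Losing only the methyl, with hydrogen on that aromatic carbon, also matters, giving a 6.8-fold lower number from compound 1 to compound 4 (0.83 log units; beyond the scatter), and the aromatic group now stands level with the tert-butyl group of compound 2, at a 1.7-fold higher number from compound 2 to compound 4 (0.24 log units; within the scatter). No evidence is available to explain these steps.

Going by these compounds, whether a chlorine or a methoxy group on that ring would cost as much as the methyl of compound 1 remains open. So does whether an ether oxygen or an amine in the chain would keep the number of compound 4.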